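Benzyl replacement for a pyridylmethyl imine in myosin-2 inhibitors

This account rests on a few compounds, and the source may have more. Where it says the series, first, only, none or still open, it means among the compounds named here.

This set of four compounds shares one core and varies only the group on a saturated chain carbon bound to a double-bonded nitrogen. Compound 1 `C/C(=N\CC(C)C)c1c(O)c2ccccc2oc1=O` carries isopropyl there, and in an assay on isolated protein for inhibition of myosin-2 (Bos taurus), read by spectrophotometry, with a stated time of 24 min (on this read-out lower numbers stand for stronger inhibition and higher numbers for weaker inhibition), compound 1 gives 34000 nM. Compound 2 `C/C(=N\Cc1ccccc1C)c1c(O)c2ccccc2oc1=O` carries 2-methylphenyl. In this assay compound 2 reaches only the limit >= 100000 nM, a limit and not a number (the limit of >= 100000 nM in this assay, at which 1 of the 3 values shown sits). Compound 3 `C/C(=N\Cc1ccccn1)c1c(O)c2ccccc2oc1=O` carries pyridin-2-yl, and in this assay compound 3 gives 22000 nM, the lowest of the two numbers, with compound 1 nearest a 1.5-fold lower number from compound 1 to compound 3 (0.19 log units; within the scatter). The step of an at least 4.5-fold lower number from compound 2 to compound 3 (0.65 log units; beyond the scatter) and the step of an at least 2.9-fold higher number from compound 1 to compound 2 (0.46 log units; beyond the scatter) both show the methylphenyl group giving the weakest result here. Compound 4 `C/C(=N\Cc1ccc(C)cc1)c1c(O)c2ccccc2oc1=O` is not yet measured; it differs from compound 3 by 4-methylphenyl in place of pyridin-2-yl on a saturated chain carbon bound to a double-bonded nitrogen. Since compound 2 sat at the limit >= 100000 nM, compound 4 is expected to give a higher number, estimated as a 3.2-fold higher number from compound 3 to compound 4 (0.50 log units; beyond the scatter), with a fair chance of again reaching the limit. The estimate for compound 4 is 70000 nM, ranging from 25000 nM to 200000 nM.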

Compound 4, half-maximal inhibitory concentration: 7900 nM
The estimate for compound 4 lay 8.9-fold (0.95 log units) above the measured number; measured number below the stated range.
By their numbers in this assay, from the lowest: compound 4; then compounds 3 and 1 (each within the scatter of the next). At a limit, above all of these: compound 2.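

A carbon-only aromatic ring can give a better result at this position than either earlier measured number suggested, with a 2.8-fold lower number from compound 3 to compound 4 (0.44 log units; beyond the scatter) and a 4.3-fold lower number from compound 1 to compound 4 (0.63 log units; beyond the scatter), the lowest number of the set in this assay. The poor result with 2-methylphenyl therefore does not extend to methylphenyl groups as a whole, since moving to 4-methylphenyl gives an at least 12-fold lower number from compound 2 to compound 4 (1.10 log units; beyond the scatter). The size of that last step is open-ended, as compound 2 gives a limit and not a number: the limit of >= 100000 nM in this assay, at which 1 of the 4 values shown sits.

As far as these compounds go, whether plain phenyl, 3-methylphenyl or 4-chlorophenyl on a saturated chain carbon bound to a double-bonded nitrogen would match 4-methylphenyl remains open. Why the two methylphenyl groups part so widely also stays unexplained.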